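Working notes: side-chain swap from compound 1 to compound 3

The source may report more compounds than this note shows. Statements on the series, on what has been measured and on what is new or still open speak of the compounds shown alone.

- compound 1 `C[C@@H](N[C@H]1CCN(c2ccc(S(=O)(=O)NC(=O)CCC(=O)O)cc2)C1)c1cccc2ccccc12` gives 10.5 h as a number
- compound 2 `C[C@@H](N[C@H]1CCN(c2ccc(C(=O)NCCCN3CCC(C(=O)O)CC3)cc2)C1)c1cccc2ccccc12` gives > 12 h as a limit

Among the compounds with values here, in an ADME assay on Caecum (Rattus norvegicus, strain Sprague-Dawley) for metabolic stability, read by LC-MS, tested at 10 uM (a lower number here means that the compound disappears faster, a higher number that the compound lasts longer), compound 1 gives 10.5 h as the only true number so far. Compound 2 reads > 12 h as a limit of the assay and not a number. Also to bear in mind is the limit of > 12 h in this assay, at which 1 of the 2 values shown sits, when reading the series.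

Compound 3 `C[C@@H](N[C@H]1CCN(c2ccc(C(=O)N[C@H](CCCCN)C(=O)O)cc2)C1)c1cccc2ccccc12` is still unmeasured. It differs from compound 1 by (5-amino-1-carboxypentyl)carbamoyl in place of ((2-carboxyethyl)carbonyl)sulfamoyl on an aromatic carbon with (5-amino-1-carboxypentyl)carbamoyl in place of ((2-carboxyethyl)carbonyl)sulfamoyl on an aromatic carbon, para to a large group. Within the data shown here, no measured step covers this change, so no shift beyond the usual scatter is expected in this assay in either direction. The expected change is a 1.0-fold higher number from compound 1 to compound 3 (0.02 log units; within the scatter) and it should stay small. Compound 3 is expected at 11 h with an estimated range from 6 h to 14 h for now.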

Compound 3, half-life: 4.3 h
Beside the measured number, compound 3's estimate is 2.6-fold (0.41 log units) above it; measured number outside the range, below it.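

In this assay, the side chain on an aromatic carbon, para to a large group, does affect the read-out: (5-amino-1-carboxypentyl)carbamoyl in place of ((2-carboxyethyl)carbonyl)sulfamoyl gives a 2.4-fold lower number from compound 1 to compound 3 (0.39 log units; beyond the scatter). Compound 2 reads > 12 h, which is a limit of the assay and not a number. Amide-linked side chains also differ from one another, with 5-amino-1-carboxypentyl in place of 3-(4-carboxypiperidin-1-yl)propyl on an amide-type nitrogen giving an at least 2.7-fold lower number from compound 2 to compound 3 (0.44 log units; beyond the scatter), and the full size of that step stays open: the limit of > 12 h in this assay, at which 1 of the 3 values shown sits.

The compounds shown do not separate the amino group of 5-amino-1-carboxypentyl from its carboxy group or from the length of its chain. From the compounds shown here alone, how a hydroxyl in place of that amino group, or a shorter chain, would read in this assay remains open.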